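The source may hold more compounds than are shown below. What is called first, only, known or untested is meant among the compounds shown, and "the series" means these compounds.

Measured so far:
compound 1 `COc1cc2c(Oc3ccc(NC(=O)c4nn(-c5ccccc5)c(=O)cc4C)cc3F)ccnc2cc1OCCCN1CCCCC1` — 160 nM
compound 2 `COc1cc2c(Oc3ccc(NC(=O)c4nn(-c5ccccc5)c(=O)cc4C)cc3F)ccnc2cc1OCCCN1CCN(C)CC1` — 130 nM

Among the compounds with values here, in a functional assay on MKN-45 cells (Homo sapiens) for inhibition, read by MTT assay, with a stated time of 72 h (a lower number here means a stronger inhibitor, a higher number a weaker inhibitor), compound 2 gives 130 nM, the lower of the two numbers, but the only measured step, a 1.2-fold lower number from compound 1 to compound 2 (0.09 log units; within the scatter), is within the scatter, so the two compounds are not separated. Compound 3 `COc1cc2c(Oc3ccc(NC(=O)c4nn(-c5ccc(F)c(F)c5)c(=O)cc4C)cc3F)ccnc2cc1OCCCN1CCN(C)CC1` differs from compound 2 by 3,4-difluorophenyl in place of phenyl on an aromatic nitrogen. Within the data shown here, no measured step touches this position; the only step on record concerns the chain end, far from it. The expected step is a 1.2-fold lower number from compound 2 to compound 3 (0.07 log units; within the scatter), nothing beyond the scatter. Compound 3 is therefore estimated at 110 nM, with a range of 40 nM to 320 nM.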

Compound 3, half-maximal inhibitory concentration: 120 nM
Compound 3: middle estimate off by 1.1-fold (0.04 log units), on the low side; measured number inside the range.
By their numbers in this assay, from the lowest: compounds 3, 2 and 1 (each within the scatter of the next).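

In this assay, the substituent on the aromatic nitrogen now has a measured step of its own, whereas the earlier step concerned only the chain end. 3,4-Difluorophenyl in place of phenyl gives a 1.1-fold lower number from compound 2 to compound 3 (0.03 log units; within the scatter), so this change does not separate the two compounds. No available evidence bears on this result.

Still open, as far as these compounds go, is whether a pyridyl or 4-methoxyphenyl group on this nitrogen would move the number beyond the scatter. Also open, from the compounds shown here alone, is whether 3,4-difluorophenyl behaves the same way with the piperidin-1-yl chain end of compound 1.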